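The source may report more compounds than this note shows. Statements on the series, on what has been measured and on what is new or still open speak of the compounds shown alone.

Going by the values given here, compound 3, `CCN(CC)C(=O)CN(c1ccc(C)cc1)S(=O)(=O)c1cccc(F)c1`, stands second highest of the three numbers measured so far in a functional assay on CHO cells for inhibition of Orexin receptor type 2 (Homo sapiens), read by FLIPR and calcium flux (a higher number here means a weaker inhibitor, a lower number a stronger inhibitor), where compound 3 gives 839 nM. Its nearest neighbour is compound 1, `CCN(CC)C(=O)CN(c1ccc(C)cc1)S(=O)(=O)c1ccc(OC)cc1`, which in this assay gives 661 nM; the step of a 1.3-fold higher number from compound 1 to compound 3 (0.10 log units; within the scatter) lies within the scatter. Furthest away is compound 2, `CCN(CC)C(=O)CN(c1ccc(C)cc1)S(=O)(=O)c1ccccc1F`, which in this assay gives 3370 nM, the gap appearing as a 4.0-fold lower number from compound 2 to compound 3 (0.60 log units; beyond the scatter). Compound 4, `CCN(CC)C(=O)CN(c1ccc(C)cc1)S(=O)(=O)c1cccc(Cl)c1`, differs from compound 3 by chloro in place of fluoro on an aromatic carbon, so the 3-fluorophenyl on the sulfonyl sulfur becomes a 3-chlorophenyl. Among the compounds with values here, no measured step exchanges one substituent for another at the same place; the three measured steps, a 5.1-fold higher number from compound 1 to compound 2 (0.71 log units; beyond the scatter), a 1.3-fold higher number from compound 1 to compound 3 (0.10 log units; within the scatter) and a 4.0-fold lower number from compound 2 to compound 3 (0.60 log units; beyond the scatter), all alter the group on the sulfonylphenyl and its place together, and only the move to 2-fluorophenyl went beyond the scatter. Keeping the place of compound 3 and changing only the substituent is therefore expected to give a step of a 1.3-fold lower number from compound 3 to compound 4 (0.11 log units; within the scatter), nothing beyond the scatter. Compound 4 is estimated at 650 nM, with a range from 250 nM to 1700 nM.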

Compound 4, half-maximal inhibitory concentration: 139 nM
Compound 4: the middle estimate sits 4.7-fold (0.67 log units) above what was measured; measured number outside the range, below it.
By their numbers in this assay, from the lowest: compound 4; then compounds 1 and 3 (each within the scatter of the next); then compound 2.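

In this assay, the substituent at this place on the ring proves to matter: chloro in place of fluoro gives a 6.0-fold lower number from compound 3 to compound 4 (0.78 log units; beyond the scatter) and is beyond the scatter, whereas the earlier 3-fluorophenyl had stood within the scatter of the 4-methoxyphenyl of compound 1. The 3-chlorophenyl also sets compound 4 apart from the other two sulfonyl groups, with a 4.8-fold lower number from compound 1 to compound 4 (0.68 log units; beyond the scatter) and a 24-fold lower number from compound 2 to compound 4 (1.38 log units; beyond the scatter), which makes compound 4 the strongest inhibitor of the four. Nothing at hand accounts for this difference between the two halogens.

The compounds shown leave open whether a bromo, methyl or trifluoromethyl group at the same place would go further than chloro. They also leave open whether chloro would hold its gain at another place on the ring, as only fluoro has been seen at a second place.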